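Pyridin-3-yl for cyclohexyl on the carbamate oxygen

A few compounds are considered here, and "the series" means these few. Any claim that something is new, unique, unknown or untested is made for them only; others in the source may bear on it.

Working notes on a small set of sulfamoyl ureas and sulfamates sharing a diisopropyl-substituted aryl core, tested in an assay on liver for inhibition of sterol O-acyltransferase 1 (Rattus norvegicus), using microsomes; on this read-out higher numbers stand for weaker inhibition and lower numbers for stronger inhibition. Compound 1 `CCCCN(C)S(=O)(=O)NC(=O)Nc1c(C(C)C)cccc1C(C)C` gives 2300 nM in this assay. Compound 2 `CCOC(=O)NS(=O)(=O)Oc1c(C(C)C)cccc1C(C)C` yields only a limit of this assay, > 50000 nM; > 50000 nM (2 entries), on both occasions it was run. Compound 3 `CC(C)c1cccc(C(C)C)c1OS(=O)(=O)NC(=O)OC1CCCCC1` gives 38000 nM, which places it at the higher of the two actual numbers recorded; the gap to compound 1 lies beyond the scatter, and compound 2 contributes no number to compare with. Compound 4 `CC(C)c1cccc(C(C)C)c1OS(=O)(=O)NC(=O)Oc1cccnc1` carries pyridin-3-yl in place of cyclohexyl on an oxygen next to a carbonyl group. For the measured compounds named here, no pair of measured compounds shows this change, so nothing in the set fixes its size or direction. The expectation for compound 4 is a step of a 1.3-fold lower number from compound 3 to compound 4 (0.10 log units; within the scatter) from compound 3, which may well fall inside the usual scatter. Compound 4 is accordingly expected to give about 30000 nM in this assay, with a range from 8000 nM to 120000 nM, and a fair chance that only a limit is returned.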

Compound 4, half-maximal inhibitory concentration: > 50000 nM
Compound 4: only a limit was reported; the forecaster's own chance of this, stated with the estimate: 35%; middle value at least 1.6-fold (0.22 log units) from the limit.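

In this assay, pyridin-3-yl in place of cyclohexyl on an oxygen next to a carbonyl group gives an at least 1.3-fold higher number from compound 3 to compound 4 (0.11 log units; that floor lies within the scatter) and so sets only a floor for the change, not its size. Compound 4 returns a limit and not a number: the limit of > 50000 nM in this assay, at which 1 of the 4 values shown sits. At this position, the entering ring nitrogen therefore brings no measurable strengthening of inhibition over cyclohexyl, and the aromatic ring does not bring the sulfamate into a better range.

How far the true value of compound 4 lies from that of compound 3 cannot be read from these data. Also open, as far as these compounds go, is how this oxygen would read with a longer alkyl chain, or with a ring bearing an amine or a carboxylic acid, in place of either ring.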